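A swap at piperazin-1-yl, starting from the assay limit

A few compounds are considered here, and "the series" means these few. Any claim that something is new, unique, unknown or untested is made for them only; others in the source may bear on it.

Of the compounds shown here, two with a shared core have so far been tested in a functional assay on HCT-116 cells (Homo sapiens) for cytotoxicity, read by MTT assay, with a stated time of 72 h; on this read-out lower numbers stand for stronger inhibition and higher numbers for weaker inhibition. One is compound 1 (`O=C(NCCCNc1c(C(=O)NCc2ccc(F)cc2)nc(Br)c2cccnc12)c1ccccc1`). Compound 1 gives > 10000 nM here, which is a limit of the assay and not a number. The other is compound 2 (`O=C(NCc1ccc(F)cc1)c1nc(Br)c2cccnc2c1N1CCNCC1`). Compound 2 gives > 10000 nM here, again only a limit. It therefore has no numerical value of its own, and the sole level seen so far is the limit of > 10000 nM in this assay, at which 2 of the 2 values shown sit ( both compounds ).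

Compound 3 (`COC(=O)CNc1c(C(=O)NCc2ccc(F)cc2)nc(Br)c2cccnc12`) has yet to be measured. It differs from compound 2 on an aromatic carbon, with ((methoxycarbonyl)methyl)amino in place of piperazin-1-yl (((methoxycarbonyl)methyl)amino in place of piperazin-1-yl on an aromatic carbon). Among the measured compounds shown here, no measured step shows what such a change does. With compound 2 at > 10000 nM as a limit, no clear step is expected in this assay, or only a small one toward stronger inhibition. The expected step is a number no higher from compound 2 to compound 3 (the limit leaves the size open) in size. For compound 3 the estimated value is 10000 nM, within an expected range from 3000 nM to 30000 nM, and the assay may well report only a limit.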

Compound 3, half-maximal inhibitory concentration: > 10000 nM
Compound 3: no number, only a limit (the forecaster's own chance of this, stated with the estimate: 65%); the middle value sits exactly at the limit.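

Compound 3 also stops at a limit of the assay and gives no number, so the steps to it from compound 2 and from compound 1 cannot be read: the limit of > 10000 nM in this assay, at which 3 of the 3 values shown sit.

The compounds shown leave open whether any of these groups on the shared core gives a measurable value, and how far these three compounds truly differ.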